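A few compounds are considered here, and "the series" means these few. Any claim that something is new, unique, unknown or untested is made for them only; others in the source may bear on it.

Measured in a physicochemical assay for solubility, read by LC-MS, in phosphate buffer, measured as kinetic solubility, with a stated time of 24 h, at 25 degrees C, at pH 7.4; a lower number here means a less soluble compound, a higher number a more soluble compound:
Compound 1 `Nc1nccc(-c2cc(OC3COC3)c3c(N)n[nH]c3c2)n1`: 383000 nM
Compound 2 `Nc1nccc(-c2ccc3c(Nc4ccccc4)n[nH]c3c2)n1`: 3000 nM

Compound 2 has the lower of these two numbers, and its gap to compound 1 lies beyond the scatter. Compound 3 `Nc1nccc(-c2ccc3cn[nH]c3c2)n1` has not been measured. It differs from compound 2 in one place: hydrogen in place of anilino on an aromatic carbon, with hydrogen in place of anilino on an aromatic carbon. For the measured compounds named here, no measured pair shows this change, so what follows is a judgement. A moderate rise beyond the scatter in this assay is expected, an estimated step of a 6.7-fold higher number from compound 2 to compound 3 (0.82 log units; beyond the scatter). Compound 3 is expected to read about 20000 nM, with an estimated range of 5000 nM to 80000 nM.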

Compound 3, solubility: 215000 nM
Compound 3: middle estimate off by 11-fold (1.03 log units), on the low side; measured number outside the range, above it.
By their numbers in this assay, from the lowest: compound 2; then compounds 3 and 1 (each within the scatter of the next).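

In this assay, for the compounds shown here, replacing anilino with hydrogen on this aromatic carbon gives a 72-fold higher number from compound 2 to compound 3 (1.86 log units; beyond the scatter), a large step and the first measured change at this position. So at this position, the compound with anilino reads far lower than the one with hydrogen. Nothing available explains the size of this step.

On these data alone, whether a methyl group or a morpholine ring at this position would read nearer compound 2 or compound 3 remains open. So does whether a carboxylic acid on the anilino ring would narrow the gap.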